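A few compounds are considered here, and "the series" means these few. Any claim that something is new, unique, unknown or untested is made for them only; others in the source may bear on it.

Measured so far:
compound 1 `ClCc1cccc(Cn2cnc3ncnc(Cl)c32)c1` — 36300 nM
compound 2 `ClCc1ccc(Cn2cnc3c(Cl)nc(Cl)nc32)cc1` — 25100 nM

In a functional assay on A498 cells (Homo sapiens) for cytotoxicity, read by sulforhodamine B assay, with a stated time of 48 h (a higher number here means a weaker inhibitor of growth, a lower number a stronger inhibitor of growth), compound 1 gives 36300 nM, the highest of the two numbers. In this assay compound 2 gives 25100 nM; the two values sit within the scatter of each other, so no order between compound 1 and compound 2 can be read from them.

Compound 3 `ClCc1cccc(Cn2cnc3nc(Cl)nc(Cl)c32)c1` has not yet been measured in this assay. It differs from compound 1 by chloro in place of hydrogen on an aromatic carbon, between two ring nitrogen atoms of the shared core. Among the measured compounds shown here, no measured pair shows this change on its own, so its size is unknown here. Compound 2 carries two chloro groups on its core yet stays within the scatter of compound 1, which gives no reason to expect a step beyond the scatter. Compound 3 is expected at 28000 nM, range 10000 nM to 70000 nM, a step of a 1.3-fold lower number from compound 1 to compound 3 (0.11 log units; within the scatter) from compound 1 that is estimated to stay within the scatter.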

Compound 3, concentration for total growth inhibition: 2810 nM
The estimate for compound 3 lay 10-fold (1.00 log units) above the measured number; the measured number lies below the stated range.
By their numbers in this assay, from the lowest: compound 3; then compounds 2 and 1 (each within the scatter of the next).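

In this assay, the aromatic carbon between two ring nitrogen atoms of the shared core proves to be a position where the series responds strongly: chloro in place of hydrogen there gives a 13-fold lower number from compound 1 to compound 3 (1.11 log units; beyond the scatter) as its step, which is large. The earlier compounds shown here offered no pair that isolated this position, whereas here this change is the only difference between the two structures. The finding rests on this single pair and applies only with the new chloro group meta to a chloro group and with the chloromethyl-bearing benzyl part of compound 1 left unchanged. No measured evidence bearing on the origin of this step is available.

On these data alone, whether an amine or a methoxy group on the same carbon would also give a lower number remains open. Among the compounds shown here, compound 2 differs from compound 3 in more than one place, so no step between them can be read.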